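Compound 4: Moving Away from the 2-Hydroxyphenyl Group

The source may report more compounds than this note shows. Statements on the series, on what has been measured and on what is new or still open speak of the compounds shown alone.

Of the compounds shown here, three sharing one core have been tested in an ADME assay on HEL cells (Homo sapiens) for cytotoxicity; a higher number here means that more compound is tolerated, a lower number that less compound is tolerated. Compound 1 `O=C(COc1cccc2ccccc12)N/N=C/c1cccc(O)c1` gives 62.7 ug/mL, and compound 2 `O=C(COc1cccc2ccccc12)N/N=C/c1ccccc1Br` gives 100 ug/mL. Compound 3 `O=C(COc1cccc2ccccc12)N/N=C/c1ccccc1O` stands lowest of the three at 3.57 ug/mL, so cells tolerate the least of it.

The next compound to be measured is compound 4 `O=C(COc1cccc2ccccc12)N/N=C/c1ccc(F)cc1`. It differs from compound 3 by one change, 4-fluorophenyl in place of 2-hydroxyphenyl on a carbon with a double bond to nitrogen.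

Among the compounds with values here, no measured step makes this exact swap, and no compound with fluorine has been tested yet. Still, two steps end at the 2-hydroxyphenyl group of compound 3: an 18-fold lower number from compound 1 to compound 3 (1.24 log units; beyond the scatter), and a 28-fold lower number from compound 2 to compound 3 (1.45 log units; beyond the scatter). Both are large. The two compounds without that group differ much less, with a 1.6-fold higher number from compound 1 to compound 2 (0.20 log units; within the scatter). Three compounds are a thin basis, but none of them goes against this picture, so removing the 2-hydroxyphenyl group may largely reverse the drop.

A large upward step is therefore expected in this assay, estimated as a 17-fold higher number from compound 3 to compound 4 (1.23 log units; beyond the scatter). Compound 4 is estimated at 60 ug/mL, with an expected range of 20 ug/mL to 100 ug/mL.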

Compound 4, half-maximal cytotoxic concentration: 71.6 ug/mL
Compound 4: the middle estimate sits 1.2-fold (0.08 log units) below what was measured; the range from low to high includes it.
By their numbers in this assay, from the lowest: compound 3; then compounds 1, 4 and 2 (each within the scatter of the next).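

In this assay, a third kind of group on the carbon with a double bond to nitrogen, and the first one carrying fluorine, gives a large rise, a 20-fold higher number from compound 3 to compound 4 (1.30 log units; beyond the scatter), which shows that the low number of compound 3 is not shared by this new group. The other two steps stay within the scatter, a 1.4-fold lower number from compound 2 to compound 4 (0.15 log units; within the scatter) and a 1.1-fold higher number from compound 1 to compound 4 (0.06 log units; within the scatter), so the 3-hydroxyphenyl, 2-bromophenyl and 4-fluorophenyl groups cannot be told apart here, and among the four compounds only the 2-hydroxyphenyl group of compound 3 stands apart. Nothing shown gives a measured reason why this one group differs from the other three.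

The compounds shown leave open whether a 2-methoxyphenyl or 2-aminophenyl group at this place would give a number as low as that of compound 3 or one in line with the other three. They also leave open what would happen on this carbon with something other than a substituted phenyl ring, such as a pyridine ring or a short alkyl chain.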